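A few compounds are considered here, and "the series" means these few. Any claim that something is new, unique, unknown or untested is made for them only; others in the source may bear on it.

Three compounds have been measured in a functional assay on HeLa cells (Homo sapiens) for cytotoxicity, read by MTT assay, with a stated time of 24 h; on this read-out lower numbers stand for stronger inhibition and higher numbers for weaker inhibition:

Compound 1, `C=CC1=C(C(=O)O)C(c2ccc(F)cc2)OC1`, gives 67400 nM.
Compound 2, `C=CC1=C(C(=O)NCc2ccccc2)C(c2ccc(F)cc2)OC1`, gives only a limit of the assay, > 100000 nM.
Compound 3, `C=CC1=C(C(=O)NCc2ccccc2)C(c2ccc(Cl)c(Cl)c2)OC1`, likewise gives only a limit of the assay, > 100000 nM.

Between compound 2 and compound 1 the change is hydroxy in place of benzylamino on a carbonyl carbon, and it made an at least 1.4-fold lower number from compound 2 to compound 1 (0.17 log units; that floor lies within the scatter). The two cores differ by 3,4-dichlorophenyl in place of 4-fluorophenyl on a saturated ring carbon; the step that the two limits leave unreadable from compound 2 to compound 3 cannot be sized, since (the limit of > 100000 nM in this assay, at which 2 of the 3 values shown sit).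

Compound 4, `C=CC1=C(C(=O)O)C(c2ccc(Cl)c(Cl)c2)OC1`, is not yet measured. It differs from compound 3 by hydroxy in place of benzylamino on a carbonyl carbon, the same change as that from compound 2 to compound 1. Resting on compound 1 with its 67400 nM and on the step of an at least 1.4-fold lower number from compound 2 to compound 1 (0.17 log units; that floor lies within the scatter), the step from compound 3 is expected to be an at least 1.4-fold lower number from compound 3 to compound 4 (0.15 log units; that floor lies within the scatter). Compound 4 is therefore estimated at 70000 nM, between 25000 nM and 200000 nM.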

Compound 4, half-maximal inhibitory concentration: 10300 nM
Estimate against measurement, compound 4: 6.8-fold (0.83 log units) above, outside the stated range (below it).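

With hydroxy in place of benzylamino on a carbonyl carbon, this assay shows an at least 9.7-fold lower number from compound 3 to compound 4 (0.98 log units; beyond the scatter). The floor of this step clears the scatter only on the core bearing 3,4-dichlorophenyl, and whether the change does more there than on the core bearing 4-fluorophenyl stays undecided: the same change on two cores in this assay, an at least 1.4-fold lower number (0.17 log units; that floor lies within the scatter) from compound 2 to compound 1 and an at least 9.7-fold lower number (0.98 log units; beyond the scatter) from compound 3 to compound 4; the limit leaves it open whether they differ. Compound 2 and compound 3 each stand at a limit of the assay, not at a number: the limit of > 100000 nM in this assay, at which 2 of the 4 values shown sit.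

The compounds shown leave open how other groups on the carbonyl carbon, such as a methoxy group or a plain amino group, would read on either core. They also leave open whether hydroxy would give a similar reading with another ring substituent, such as 4-methoxyphenyl.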